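The source may hold more compounds than are shown below. What is called first, only, known or untested is meant among the compounds shown, and "the series" means these compounds.

Measured compounds:
- compound 1, `Cc1cc(C(=O)NCN2CCC(c3cccc[n+]3[O-])CC2)ccc1F`: 67%
- compound 2, `Cc1cccc(C(=O)NCN2CCC(c3nccs3)CC2)c1`: 71%
- compound 3, `COc1ccccc1C1CCN(CC(=O)Nc2cccc(C)c2)CC1`: 43%

In a functional assay on HEK293 cells for agonist activity at D(4) dopamine receptor (Homo sapiens), read by FLIPR (a higher number here means a larger maximal response, a lower number a smaller maximal response), compound 1 stands second highest of the three numbers. Its nearest neighbour is compound 2, whose value lies within the usual scatter of that of compound 1, so no order can be read between the two. Compound 3 lies furthest away, beyond the scatter, with the lower maximal response of the three.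

Compound 4, `O=C(NCN1CCC(c2cccc[n+]2[O-])CC1)c1ccc(F)c(Cl)c1`, is not yet measured in this assay. It differs from compound 1 in one place: chloro in place of methyl on an aromatic carbon. Within the data shown here, no measured pair in this set shows the effect of such an exchange, so the expectation rests on the single heavy atom swapped and on the position of compound 1 in the set. Compound 4 is expected to change by about a number 2 percentage points lower from compound 1 to compound 4 (within the scatter) in this assay, a step that should stay within the scatter. For compound 4 an efficacy of about 65% is estimated, between 50% and 80%.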

Compound 4, largest response reached (reported as efficacy), in percent of the reference or control that the assay uses: 67%
Compound 4: middle estimate off by 2 percentage points, on the low side, and the stated range covers the measured number.
By their numbers in this assay, from the lowest: compound 3; then compounds 1, 4 and 2 (each within the scatter of the next).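

In this assay, among these compounds, the change from 4-fluoro-3-methylphenyl to 3-chloro-4-fluorophenyl gives no change at the digits printed from compound 1 to compound 4 (within the scatter) and is the first single exchange in this set that can be read directly. At this place, ortho to a fluoro group, chloro and methyl cannot be told apart by maximal response. Nothing available explains this result.

From the compounds shown here alone, whether a nitrile, a trifluoromethyl or an amine at the same carbon would keep the response there stays open. So does whether the same exchange reads alike on the core of compound 2 .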